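The source may hold more compounds than are shown below. What is called first, only, known or untested is meant among the compounds shown, and "the series" means these compounds.

Three compounds share one core and differ only in the group carried on the ring nitrogen. In a functional assay on MDA-MB-231 cells (Homo sapiens) for inhibition, read by sulforhodamine B assay, tested at 10 uM (on this read-out lower numbers stand for less inhibition and higher numbers for more inhibition at the one concentration tested (going by the name of the read-out)), compound 1 `CN(C)c1ccc(C2CC(c3ccc(-n4cncn4)cc3)=NN2C(=O)CCCl)cc1` gives 3.7%. Compound 2 `COC(=O)CC(=O)N1N=C(c2ccc(-n3cncn3)cc2)CC1c1ccc(N(C)C)cc1` gives 6.8% in this assay, and compound 3 `CN(C)c1ccc(C2CC(c3ccc(-n4cncn4)cc3)=NN2C(=O)/C=C/c2ccccc2)cc1` gives 8.5% in this assay. Compound 3 thus holds the highest of the three numbers, but its distances to compound 2 and to compound 1 both lie within the scatter, so no order among the three can be claimed. The steps of a number 3.1 percentage points higher from compound 1 to compound 2 (within the scatter), a number 4.8 percentage points higher from compound 1 to compound 3 (within the scatter) and a number 1.7 percentage points higher from compound 2 to compound 3 (within the scatter) all stay within the scatter. Compound 4 `CN(C)c1ccc(C2CC(c3ccc(-n4cncn4)cc3)=NN2S(=O)(=O)c2ccc(F)cc2)cc1` differs from compound 3 by (4-fluorophenyl)sulfonyl in place of (2-phenylethenyl)carbonyl on an amine nitrogen in a ring. For the measured compounds named here, no measured step exchanges a carbonyl-linked group for a sulfonyl-linked group on that nitrogen, so the three within-scatter steps are the only guide, and they give no reason to expect a step beyond the scatter in this assay. The estimated step is a number 0.5 percentage points lower from compound 3 to compound 4 (within the scatter). Compound 4 is therefore expected to give 8% in this assay, with an expected range from 0% to 28%.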

Compound 4, a percentage reported as inhibition, at one concentration (the size of the read-out at that concentration, not a potency): 12.1%
Compound 4: the middle estimate sits 4.1 percentage points below what was measured; low and high end bracket the measured number.
By their numbers in this assay, from the lowest: compounds 1, 2, 3 and 4 (each within the scatter of the next).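

Placing a sulfonyl link on this ring nitrogen opens a kind of change that the carbonyl-linked compounds could not show, and in this assay the (4-fluorophenyl)sulfonyl group gives a number 3.6 percentage points higher from compound 3 to compound 4 (within the scatter) and a number 5.3 percentage points higher from compound 2 to compound 4 (within the scatter) and a number 8.4 percentage points higher from compound 1 to compound 4 (within the scatter) as its three steps. At this position, then, neither the exchange of the carbonyl link for a sulfonyl link nor the change of the attached group separates compound 4 from the other three compounds. Nothing measured here speaks to the reason for these numbers.

From the compounds shown here alone, whether an acyl group carrying a longer chain with a terminal amine, or a methylsulfonyl group, on this nitrogen would step beyond the scatter remains open. So does the effect of replacing the 4-(dimethylamino)phenyl group, which all four compounds share.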